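Urea aryl swap: dichlorophenyl to trifluoromethylphenyl

The source may report more compounds than this note shows. Statements on the series, on what has been measured and on what is new or still open speak of the compounds shown alone.

Compound 1 `COc1cc(Cl)cc(-c2nn(-c3cccc(NC(=O)Nc4cc(C(F)(F)F)cc(C(F)(F)F)c4)c3)cc2-c2ccncc2)c1`: 8%
Compound 2 `COc1cc(Cl)cc(-c2nn(-c3cccc(NC(=O)Nc4ccc(Cl)c(Cl)c4)c3)cc2-c2ccncc2)c1`: 89%

In a functional assay on NCI-H23 cells (Homo sapiens) for inhibition, read by sulforhodamine B assay, with a stated time of 48 h, tested at 1 uM (a lower number here means a stronger effect, a higher number a weaker effect of the compound at the concentration tested), compound 2 gives 89%, the highest of the two numbers measured, and compound 1 sits far lower at 8%, a gap well beyond the scatter. Both compounds share the same core; they differ only in the aryl group carried by the urea. Compound 3 `COc1cc(Cl)cc(-c2nn(-c3cccc(NC(=O)Nc4cccc(C(F)(F)F)c4)c3)cc2-c2ccncc2)c1` has not yet been measured in this assay. Relative to compound 2 the change is 3-(trifluoromethyl)phenyl in place of 3,4-dichlorophenyl on an amide-type nitrogen. Among the measured compounds shown here, no measured pair shows this step directly, so its size is uncertain. Because compound 1, which carries two trifluoromethyl groups on the urea aryl, reaches 8%, a single trifluoromethyl group is expected to move the number downward, beyond the scatter but probably not all the way. The step from compound 2 to compound 3 is estimated at a number 44 percentage points lower from compound 2 to compound 3 (beyond the scatter). Compound 3 is therefore expected to give about 45%, within a range from 10% to 85%.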

Compound 3, a percentage reported as activity, at one concentration (the size of the read-out at that concentration, not a potency): 71%
For compound 3 the middle estimate is 26 percentage points below the measured one; low and high end bracket the measured number.
By their numbers in this assay, from the lowest: compound 1; then compound 3; then compound 2.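

In this assay the urea aryl position now shows a graded response: 3-(trifluoromethyl)phenyl in place of 3,4-dichlorophenyl gives a number 18 percentage points lower from compound 2 to compound 3 (beyond the scatter) as a modest step, while hydrogen in place of one trifluoromethyl on an aromatic carbon gives a number 63 percentage points higher from compound 1 to compound 3 (beyond the scatter) as a large one. A single trifluoromethyl group therefore keeps only a small part of the low reading seen with two, and compound 3 stays much closer to compound 2 than to compound 1. Nothing available gives a cause for either step.

The compounds shown leave open how a methoxy group, a nitrile or a dimethylamino group on this aryl would read. They also leave open whether an aryl carrying both a chlorine and a trifluoromethyl group would fall nearer compound 1 or compound 3.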